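Furan-3-yl to pyridin-2-yl on the shared core

The source may report more compounds than this note shows. Statements on the series, on what has been measured and on what is new or still open speak of the compounds shown alone.

In a functional assay on MCF7 cells (Homo sapiens) for inhibition, with a stated time of 96 h (on this read-out lower numbers stand for stronger inhibition and higher numbers for weaker inhibition), compound 1 `COc1cc(C(=O)c2cn(-c3cccc(C)c3)cc2-c2ccoc2)cc(OC)c1OC` gives 21 nM and compound 2 `COc1cc(C(=O)c2cn(-c3ccc(C)cc3)cc2-c2ccoc2)cc(OC)c1OC` gives 18 nM. Within the data shown here, these are the only two values so far, and a 1.2-fold lower number from compound 1 to compound 2 (0.07 log units; within the scatter), so compound 1 cannot be ranked apart from compound 2.

Compound 3 `COc1cc(C(=O)c2cn(-c3cccc(C)c3)cc2-c2ccccn2)cc(OC)c1OC` keeps the 3-methylphenyl group of compound 1 and differs from it at one other place: pyridin-2-yl in place of furan-3-yl on an aromatic carbon. In short, pyridin-2-yl stands in place of furan-3-yl on an aromatic carbon.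

Among the measured compounds shown here, the single measured step concerns the group on the aromatic nitrogen and does not touch this place. For the measured compounds named here, it shows only that one change elsewhere on the core stayed within the scatter. Going by the values given here, no measurement yet tests any replacement of furan-3-yl, so neither the size nor the direction of the step is fixed by the data. A modest move to a higher number in this assay is tentatively expected, and the range is kept wide. The expected change is a 1.9-fold higher number from compound 1 to compound 3 (0.28 log units; within the scatter). For compound 3 the estimated value is 40 nM, with an expected range from 10 nM to 200 nM.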

Compound 3, half-maximal inhibitory concentration: 140 nM
Beside the measured number, compound 3's estimate is 3.5-fold (0.54 log units) below it; the measured number falls inside the stated range.
By their numbers in this assay, from the lowest: compounds 2 and 1 (each within the scatter of the next); then compound 3.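

Working notes on the furan-3-yl position: pyridin-2-yl in place of furan-3-yl brings a 6.7-fold higher number from compound 1 to compound 3 (0.82 log units; beyond the scatter) in this assay and so gives the series its first step beyond the scatter, whereas the only earlier step, on the aromatic nitrogen, stayed within it. This aromatic carbon, next to the ring atom that bears a large group, is therefore not indifferent to the group it carries, even though the leaving and entering groups have the same counts of hydrogen-bond donors and acceptors and neither has a net charge; what differs in the count is ring size and the hetero atom, and this one step cannot separate the two. No measurement in hand speaks to the cause of the step.

Open, from the compounds shown here alone, is whether the six-membered ring or the nitrogen of pyridin-2-yl accounts for the step: phenyl or pyridin-3-yl at this place would separate them, and thiophen-3-yl would test a five-membered aromatic ring with sulfur as the hetero atom. Also open, going by these compounds, is whether the step carries over to the 4-methylphenyl group of compound 2 on the aromatic nitrogen.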